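The source may hold more compounds than are shown below. What is called first, only, known or untested is meant among the compounds shown, and "the series" means these compounds.

Compound 1 `Cc1cccc(N2C(=O)CSC2c2cccc(C(=O)NCCCCc3ccccc3)c2)c1` and compound 2 `COc1cc(F)ccc1N1C(=O)CSC1c1cccc(C(=O)NCCCCc2ccccc2)c1` share one core and differ only in the group on the ring amide nitrogen. In a functional assay on U2OS cells (Homo sapiens) for inhibition, read by CCK-8 assay, with a stated time of 72 h, tested at 1 uM (a higher number here means more inhibition at the concentration tested (going by the name of the read-out), a lower number less inhibition), compound 1 gives 39%, while compound 2 gives 34%, the lower of the two numbers, a gap that stays within the scatter, as the step of a number 5 percentage points lower from compound 1 to compound 2 (within the scatter) shows. Compound 3 `O=C(NCCCCc1ccccc1)c1cccc(C2SCC(=O)N2c2cccc(F)c2)c1` carries 3-fluorophenyl in place of 4-fluoro-2-methoxyphenyl on an amide-type nitrogen in a ring. Within the data shown here, only that one measured step bears on this change, and it was small, so no movement beyond the scatter is expected in this assay. Compound 3 is therefore estimated at 37%, within 22% to 52%. That estimate means an expected step of a number 3 percentage points higher from compound 2 to compound 3 (within the scatter).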

Compound 3, a percentage reported as inhibition, at one concentration (the size of the read-out at that concentration, not a potency): 39%
Compound 3: the middle estimate sits 2 percentage points below what was measured; low and high end bracket the measured number.
By their numbers in this assay, from the lowest: compounds 2, 1 and 3 (each within the scatter of the next).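

In this assay, 3-fluorophenyl in place of 4-fluoro-2-methoxyphenyl gives a number 5 percentage points higher from compound 2 to compound 3 (within the scatter), and fluoro in place of methyl on an aromatic carbon gives no change at the digits printed from compound 1 to compound 3 (within the scatter). This position on the ring amide nitrogen has now taken three different substituted phenyl groups, in compounds 1, 2 and 3, with no step beyond the scatter, and the methoxy group shows no separate effect. No measurement shown gives a cause for these readings. Still open, from the compounds shown here alone, is whether a group of another kind here, such as a pyridine ring, a carboxylic acid or an amine, would move the number beyond the scatter.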